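The source may hold more compounds than are shown below. What is called first, only, known or untested is meant among the compounds shown, and "the series" means these compounds.

In an assay on HL-60 cells for inhibition of glutathione S-transferase P (Homo sapiens), read by spectrophotometry, tested at 20 uM (on this read-out higher numbers stand for more inhibition at the one concentration tested (going by the name of the read-out) and lower numbers for less inhibition), compound 2 `COc1ccccc1/C=C1\CN(CC(=O)O)c2c(C)cccc2C1=O` gives 4.72%, the lowest of the three numbers here. Compound 1 `Cc1cccc2c1N(CC(=O)O)C/C(=C\c1cccc(O)c1)C2=O` gives 75.6%, and compound 3 `Cc1ccc(/C=C2\CN(CC(=O)O)c3c(C)cccc3C2=O)cc1` gives 46.8%. The two steps touching compound 2, a number 70.9 percentage points lower from compound 1 to compound 2 (beyond the scatter) and a number 42.1 percentage points higher from compound 2 to compound 3 (beyond the scatter), show that exchanging the whole ring on the double-bonded chain carbon moves this assay by large amounts. Compound 4 `COc1cccc(/C=C2\CN(CC(=O)O)c3c(C)cccc3C2=O)c1OC` keeps the core of compound 2 and differs in one place: methoxy in place of hydrogen on an aromatic carbon. The measured steps swap rings rather than add a group, so they guide only roughly. A moderate rise is expected, estimated as a number 20.3 percentage points higher from compound 2 to compound 4 (beyond the scatter). Compound 4 is therefore expected to give about 25%, with a range from 5% to 55%.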

Compound 4, a percentage reported as inhibition, at one concentration (the size of the read-out at that concentration, not a potency): 8.1%
Beside the measured number, compound 4's estimate is 16.9 percentage points above it; measured number inside the range.
By their numbers in this assay, from the lowest: compounds 2 and 4 (each within the scatter of the next); then compound 3; then compound 1.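

In this assay, putting methoxy in place of hydrogen on this aromatic carbon, ortho to a methoxy group and meta to a large group, gives a number 3.4 percentage points higher from compound 2 to compound 4 (within the scatter). At this position, then, the added methoxy cannot be told apart from hydrogen, and the large steps seen when whole rings were exchanged do not recur with this smaller change. Nothing available explains this result. On these data alone, whether an amine or a chlorine atom on this carbon would also leave the read-out unmoved stays open. So does whether methoxy here gives the same result without the neighbouring methoxy group already present in compound 2.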